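Swapping an iodo-methoxy aryl for a fluoro-methyl aryl

The source may hold more compounds than are shown below. What is called first, only, known or untested is meant among the compounds shown, and "the series" means these compounds.

Compound 1 `COc1cc(NC(=O)Nc2cc(Nc3ccc(C)c(F)c3)ncn2)cc(OC)c1`: 30.6%
Compound 2 `COc1cc(NC(=O)Nc2cc(Nc3cc(F)ccc3OC)ncn2)cc(OC)c1`: 38%
Compound 3 `COc1cc(NC(=O)Nc2cc(Nc3cc(I)ccc3OC)ncn2)cc(OC)c1`: 55%

Of the compounds shown here, three built on a shared core have been tested in a functional assay on NCI-H520 cells (Homo sapiens) for inhibition, read by MTT assay, with a stated time of 48 h, tested at 10 uM; on this read-out lower numbers stand for less inhibition and higher numbers for more inhibition at the one concentration tested (going by the name of the read-out). In this assay compound 3 stands highest of the three numbers: the step of a number 17 percentage points higher from compound 2 to compound 3 (beyond the scatter) and the step of a number 24.4 percentage points higher from compound 1 to compound 3 (beyond the scatter) both lie beyond the scatter, while the step of a number 7.4 percentage points higher from compound 1 to compound 2 (within the scatter) does not.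

Compound 4 `COc1cc(NC(=O)Nc2cc(Nc3cc(C)cc(F)c3)ncn2)cc(OC)c1` has not yet been measured. It differs from compound 3 in one place: 3-fluoro-5-methylphenyl in place of 5-iodo-2-methoxyphenyl on a nitrogen on an aromatic ring. The iodine and the methoxy group that set compound 3 apart are both gone, and the new group, carrying only fluoro and methyl, is close in kind to the 3-fluoro-4-methylphenyl of compound 1. The two measured steps that bear on this change are therefore those leading into compound 3 from compound 1 and compound 2, modest gains both beyond the scatter, and the step from compound 3 to compound 4 undoes most of what those steps introduced.

A drop of about that size is expected, a number 23 percentage points lower from compound 3 to compound 4 (beyond the scatter), putting compound 4 back near compound 1. Compound 4 is estimated at 32%, with a range from 18% to 48%.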

Compound 4, a percentage reported as inhibition, at one concentration (the size of the read-out at that concentration, not a potency): 24.5%
Compound 4: middle estimate off by 7.5 percentage points, on the high side; measured number inside the range.
By their numbers in this assay, from the lowest: compounds 4, 1 and 2 (each within the scatter of the next, the first and the last beyond it); then compound 3.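

In this assay, the group on the nitrogen proves able to move the number a long way, with a number 30.5 percentage points lower from compound 3 to compound 4 (beyond the scatter), and the fluoro-bearing pair also separates, with a number 13.5 percentage points lower from compound 2 to compound 4 (beyond the scatter), so 3-fluoro-5-methylphenyl reads apart from both methoxy-bearing groups. That does not make a simple rule about the methoxy group, as compound 1 also lacks it yet stands within the scatter of compound 2, while the two fluoro-methyl groups cannot be told apart, with a number 6.1 percentage points lower from compound 1 to compound 4 (within the scatter). No measurement at hand explains why these groups differ.

Still open, going by these compounds, is how much of the gain in compound 3 belongs to the iodo group and how much to the methoxy group, as the step to compound 4 changes both at once. Also open, on these data alone, is how the number would respond to bromo in place of iodo on the same aromatic carbon, or to an amine or a carboxylic acid on this aromatic ring.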